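Nitro for hydrogen on a non-cytotoxic pair

The source may report more compounds than this note shows. Statements on the series, on what has been measured and on what is new or still open speak of the compounds shown alone.

Compound 1, `COc1ccc2c(c1)OC(c1ccc(Cl)cc1)C(c1ccccc1)C2=O`: in an ADME assay on PBMC cells (Homo sapiens) for cytotoxicity, read by MTT assay, with a stated time of 5 days (on this read-out lower numbers stand for higher toxicity in this test and higher numbers for lower toxicity in this test), compound 1 gives > 2500000 nM, a limit of the assay.
Compound 2, `CCOc1ccc2c(c1)OC(c1ccccc1)C(c1ccccc1)C2=O`: in this assay compound 2 gives > 2500000 nM, a limit of the assay.

The two measured compounds share one core and differ in the substituent on one of the two pendant rings and in the alkoxy group on the fused ring. Neither gives a number: both sit at the limit of > 2500000 nM in this assay, at which 2 of the 2 values shown sit. Among the compounds with values here, compound 2 therefore stands at the limit, alongside the only other value in hand, and the pair offers no measured step and no order between them.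

Compound 3, `CCOc1ccc2c(c1)OC(c1ccc([N+](=O)[O-])cc1)C(c1ccccc1)C2=O`, is the next member. It keeps everything of compound 2 except that (nitro in place of hydrogen on an aromatic carbon). Within the data shown here, with no measured step to lean on, the expectation for the step from compound 2 to compound 3 in this assay is none beyond the scatter, so a number no higher from compound 2 to compound 3 (the limit leaves the size open) is what is estimated. Compound 3 is accordingly expected to give about 2500000 nM, within 500000 nM to 6000000 nM, most likely again reported only as the assay limit.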

Compound 3, half-maximal cytotoxic concentration: 1360000 nM
For compound 3 the middle estimate is 1.8-fold (0.26 log units) above the measured one; low and high end bracket the measured number.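

Compound 3 is the only one of the three compounds shown that gives a number rather than a limit in this assay, so this position on the pendant ring can carry a change that brings the read-out onto a measurable value. Going from phenyl to 4-nitrophenyl gives an at least 1.8-fold lower number from compound 2 to compound 3 (0.26 log units; that floor lies within the scatter), and this floor alone does not separate the two compounds beyond the scatter, so the data do not establish that nitro raises toxicity in this test. The true size of the step stays open, since the starting point is not a number but a limit: the limit of > 2500000 nM in this assay, at which 2 of the 3 values shown sit.

On these data alone, whether another group at this place, such as an amine or a carboxylic acid, would also give a number in this assay remains open, and so does whether such a number would be tied to nitro itself or would follow from any substituent there. As far as these compounds go, it is equally open whether nitro would act in the same way with a longer chain in place of the alkoxy group on the fused ring.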